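Fluoro in Place of Methoxy on an Aromatic Carbon

This account rests on a few compounds, and the source may have more. Where it says the series, first, only, none or still open, it means among the compounds named here.

In an ADME assay on THP-1 cells (Homo sapiens) for cytotoxicity, read by flow cytometry and propidium iodide staining, with a stated time of 72 h (a lower number here means a stronger inhibitor, a higher number a weaker inhibitor), compound 1 (`CC(=O)Nc1ccc2oc(-c3ccccc3F)c(O)c(=O)c2c1`) gives 47000 nM. Compound 2 (`COc1ccccc1-c1oc2ccc(N)cc2c(=O)c1O`) gives 102000 nM, the higher of the two numbers, and the gap between them lies beyond the scatter. Compound 3 (`Nc1ccc2oc(-c3ccccc3F)c(O)c(=O)c2c1`) has not yet been measured. It departs from compound 2 by fluoro in place of methoxy on an aromatic carbon. Among the compounds with values here, no measured pair shows this change, and a small drop in the number is expected, perhaps none beyond the scatter. The estimated step is a 1.4-fold lower number from compound 2 to compound 3 (0.13 log units; within the scatter). For compound 3 the expected value is 75000 nM, within a range of 30000 nM to 170000 nM.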

Compound 3, half-maximal inhibitory concentration: 38000 nM
Beside the measured number, compound 3's estimate is 2.0-fold (0.30 log units) above it; the range from low to high includes it.
By their numbers in this assay, from the lowest: compounds 3 and 1 (each within the scatter of the next); then compound 2.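

In this assay, within the data shown here, fluoro in place of methoxy on an aromatic carbon, ortho to a large group, gives a 2.7-fold lower number from compound 2 to compound 3 (0.43 log units; beyond the scatter) and so provides the first measured pair for this change. With fluoro kept at that place, hydrogen in place of acetyl on the nitrogen gives a 1.2-fold lower number from compound 1 to compound 3 (0.09 log units; within the scatter) and so leaves the two compounds level. Nothing measured here accounts for either step. As far as these compounds go, whether chloro or hydroxyl at this place would read like fluoro or like methoxy stays open, as does whether the methoxy-to-fluoro step holds with acetyl on the nitrogen.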